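Phenyl Restored on the Methoxycarbonyl-Bearing Chain

A few compounds are considered here, and "the series" means these few. Any claim that something is new, unique, unknown or untested is made for them only; others in the source may bear on it.

Compound 2 `COC(=O)[C@@H](C)NC(=O)c1[nH]cnc1C(=O)Nc1ccc(Cl)c(Cl)c1` sits at the edge of what a functional assay on HL-60 cells (Homo sapiens), with a stated time of 2 days (a lower number here means a stronger inhibitor, a higher number a weaker inhibitor), reports: in this assay compound 2 gives > 62500 nM, which is a limit and not a number. Compound 1 `C[C@H](NC(=O)c1[nH]cnc1C(=O)Nc1ccc(Cl)c(Cl)c1)c1ccccc1` gives 9200 nM in this assay, and the step of an at least 6.7-fold higher number from compound 1 to compound 2 (0.83 log units; beyond the scatter) ends at the limit (the limit of > 62500 nM in this assay, at which 1 of the 2 values shown sits). Compound 3 `COC(=O)[C@H](NC(=O)c1[nH]cnc1C(=O)Nc1ccc(Cl)c(Cl)c1)c1ccccc1` carries phenyl in place of methyl on a saturated chain carbon bound to an amide-type nitrogen and a carbonyl carbon. That single measured step bears on it only indirectly, since compound 3 keeps the methoxycarbonyl of compound 2 while regaining the phenyl of compound 1; a modest fall in the number is therefore expected, an at least 3.1-fold lower number from compound 2 to compound 3 (0.49 log units; beyond the scatter). Compound 3 is estimated at 20000 nM, between 5000 nM and 80000 nM.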

Compound 3, half-maximal inhibitory concentration: 17300 nM
Compound 3: the middle estimate sits 1.2-fold (0.06 log units) above what was measured, within the range that was stated.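

With the methoxycarbonyl kept, phenyl in place of methyl on this saturated chain carbon gives an at least 3.6-fold lower number from compound 2 to compound 3 (0.55 log units; beyond the scatter). That step is only a bound, since the value of compound 2 is a limit and not a number: the limit of > 62500 nM in this assay, at which 1 of the 3 values shown sits.

With the phenyl kept, methoxycarbonyl in place of methyl gives a 1.9-fold higher number from compound 1 to compound 3 (0.27 log units; within the scatter), so the weakness of compound 2 goes with the absent phenyl and not with the methoxycarbonyl as such. On these data alone, whether a carboxylic acid in place of the methoxycarbonyl, or benzyl in place of the phenyl, would shift the number in this assay stays open.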